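Morpholine for piperidine on the dithiocarbamate of two chromone cores

The compounds below may be only part of what the source reports. "The series", "measured", "known", "first", "only" and "open" are said of these compounds alone.

Measured so far in a functional assay on LM7 cells (Homo sapiens) for antiproliferative activity, read by MTT assay, with a stated time of 72 h; on this read-out lower numbers stand for stronger inhibition and higher numbers for weaker inhibition:
- compound 1, `O=c1cc(CSC(=S)N2CCCCC2)oc2cc(Cl)ccc12`: 13800 nM
- compound 2, `O=c1cc(CSC(=S)N2CCOCC2)oc2cc(Cl)ccc12`: > 25000 nM
- compound 3, `CCOC(=O)c1cc(=O)c2cc(CSC(=S)N3CCCCC3)ccc2o1`: 16900 nM

Compound 2 reaches only a limit in this assay, > 25000 nM, and no number is obtained there (the limit of > 25000 nM in this assay, at which 1 of the 3 values shown sits). Compound 2 differs from compound 1 by morpholin-4-yl in place of piperidin-1-yl on a thiocarbonyl carbon, and the step is an at least 1.8-fold higher number from compound 1 to compound 2 (0.25 log units; that floor lies within the scatter), a floor that lies within the scatter. Compound 3 carries a different core; the difference between the core of compound 1 and the core of compound 3 is not broken down here. Compound 3 and compound 1 give numbers within the scatter of each other in this assay.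

Compound 4, `CCOC(=O)c1cc(=O)c2cc(CSC(=S)N3CCOCC3)ccc2o1`, is not yet measured. It differs from compound 3 by morpholin-4-yl in place of piperidin-1-yl on a thiocarbonyl carbon, the same change as from compound 1 to compound 2, at the same place. Because the measured step was an at least 1.8-fold higher number from compound 1 to compound 2 (0.25 log units; that floor lies within the scatter), the step from compound 3 to compound 4 is expected to be about a 1.8-fold higher number from compound 3 to compound 4 (0.25 log units; within the scatter). Compound 4 is therefore estimated at 30000 nM, expected between 17000 nM and 60000 nM, quite possibly again only as a limit.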

Compound 4, half-maximal inhibitory concentration: > 25000 nM
Compound 4: only a limit was reported; the forecaster's own chance of this, stated with the estimate: 65%; the middle value is on the limit's open side.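

In this assay compound 4 gives only a limit, > 25000 nM, and no number. Morpholin-4-yl in place of piperidin-1-yl on a thiocarbonyl carbon gives an at least 1.4-fold higher number from compound 3 to compound 4 (0.17 log units; that floor lies within the scatter), so the core of compound 3 does not run against the direction seen on the core of compound 1, though it does not establish that direction either. The change can be followed from one core to the other only as far as the limit allows, and its size stays unknown on both cores: the same change on two cores in this assay, an at least 1.8-fold higher number (0.25 log units; that floor lies within the scatter) from compound 1 to compound 2 and an at least 1.4-fold higher number (0.17 log units; that floor lies within the scatter) from compound 3 to compound 4; the limit leaves it open whether they differ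

Still open, on these data alone, is whether another amine on the thiocarbonyl carbon, such as pyrrolidin-1-yl or 4-methylpiperazin-1-yl, would give a number rather than a limit in this assay. Also open, as far as these compounds go, is how a carboxylic acid in place of the ethyl ester of compound 3 would read there, with either piperidin-1-yl or morpholin-4-yl on the thiocarbonyl carbon.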